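This account rests on a few compounds, and the source may have more. Where it says the series, first, only, none or still open, it means among the compounds named here.

Measured compounds in a functional assay on PC-3 cells (Homo sapiens) for cytotoxicity, read by MTT assay, with a stated time of 72 h; a higher number here means a weaker inhibitor, a lower number a stronger inhibitor:

- compound 1, `Cc1cc(Nc2cccc(C(F)(F)F)c2)nc(SCc2nc3ccccc3[nH]2)n1`, gives > 100000 nM, a limit of the assay rather than a number.
- compound 2, `Cc1cc(Nc2ccc(F)cc2)nc(SCc2nc3ccccc3[nH]2)n1`, gives 56200 nM.
- compound 3, `Cc1cc(NC(C)C)nc(SCc2nc3ccccc3[nH]2)n1`, gives > 100000 nM, again a limit of the assay.

Among the measured compounds shown here, compound 2 is therefore the only member of the set with a measured number in this assay; the two other values are limits, as noted in the limit of > 100000 nM in this assay, at which 2 of the 3 values shown sit.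

The compound not yet measured is compound 4, `Cc1cc(N(C)Cc2ccccc2)nc(SCc2nc3ccccc3[nH]2)n1`. It differs from compound 2 in one place: benzyl(methyl)amino in place of (4-fluorophenyl)amino on an aromatic carbon. The secondary aromatic amine of compound 2 is thus replaced by a tertiary amine carrying a benzyl and a methyl group, with no hydrogen-bond donor left at that position.

For the measured compounds named here, the one measured step that bears on this change is the replacement of the 4-fluorophenyl group by isopropyl on the same nitrogen, an at least 1.7-fold higher number from compound 2 to compound 3 (0.25 log units; that floor lies within the scatter), which carried the value from a number to the limit of the assay. The change to compound 4 also removes the 4-fluorophenyl group and the amine hydrogen, though it keeps an aromatic ring, so a move in the same direction, toward weaker inhibition, is expected, with a fair chance that only a limit is reported.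

Compound 4 is estimated at 110000 nM in this assay, within 40000 nM to 300000 nM, which is expected to correspond to a step of a 2.0-fold higher number from compound 2 to compound 4 (0.29 log units; within the scatter).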

Compound 4, half-maximal inhibitory concentration: > 100000 nM
Compound 4: a limit, no number; the forecaster's own chance of this, stated with the estimate: 55%; the middle value lies beyond the limit too.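

In this assay the exchange of (4-fluorophenyl)amino for benzyl(methyl)amino on this aromatic carbon gives an at least 1.7-fold higher number from compound 2 to compound 4 (0.25 log units; that floor lies within the scatter) and only this floor on the size of the change can be read. Compound 4 gives > 100000 nM, which is a limit of the assay and not a number. Unlike the isopropylamino group of compound 3, benzyl(methyl)amino keeps a six-membered aromatic ring on the nitrogen, yet compound 4 gives no number either, so the presence of such a ring in this group is not enough for a measured value; the step between compound 3 and compound 4 cannot be read, and compound 2 stays the only compound with a number, the rest of the set reading as follows: the limit of > 100000 nM in this assay, at which 3 of the 4 values shown sit.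

Going by these compounds, compound 4 changes the hydrogen-bond donor count and brings in the benzyl and methyl groups in a single exchange, so the part of the change that matters stays open. Benzylamino or (4-fluorophenyl)(methyl)amino at this position would separate these features, and a morpholine would test a tertiary amine without an aromatic ring.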